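Antiproliferative Thiophene Carboxamides: From Compound 3 to Compound 4

This account rests on a few compounds, and the source may have more. Where it says the series, first, only, none or still open, it means among the compounds named here.

Measured compounds:
Compound 1, `Cc1ccc(C(=O)Nc2sc3c(c2C(N)=O)CCN(C(=S)Nc2ccccc2Cl)C3)cc1`, 26300 nM
Compound 2, `NC(=O)c1c(NC(=O)c2cccc([N+](=O)[O-])c2)sc2c1CCN(C(=S)Nc1ccccc1Cl)C2`, 40300 nM
Compound 3, `Cc1ccc(C(=O)Nc2sc3c(c2C(N)=O)CCN(C(=S)Nc2cc(C(F)(F)F)cc(C(F)(F)F)c2)C3)cc1`, 17100 nM

Of the compounds shown here, three have been measured in a functional assay on HeLa cells (Homo sapiens) for antiproliferative activity, with a stated time of 24 h; on this read-out lower numbers stand for stronger inhibition and higher numbers for weaker inhibition. Compound 1 gives 26300 nM, compound 2 gives 40300 nM and compound 3 gives 17100 nM. Compound 3 has the lowest of the three numbers, but its gap to compound 1 is within the scatter, so no order between them is claimed; only compound 2 lies beyond the scatter from compound 3.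

Compound 1 and compound 2 differ at one place: 3-nitrophenyl in place of 4-methylphenyl on a carbonyl carbon In this assay this change gave a 1.5-fold higher number from compound 1 to compound 2 (0.19 log units; within the scatter).

Compound 4, `NC(=O)c1c(NC(=O)c2cccc([N+](=O)[O-])c2)sc2c1CCN(C(=S)Nc1cc(C(F)(F)F)cc(C(F)(F)F)c1)C2`, has not been measured. It stands to compound 3 as compound 2 stands to compound 1: 3-nitrophenyl in place of 4-methylphenyl on a carbonyl carbon The difference between the core of compound 3 and the core of compound 1 is not broken down here. The place of the change is described in the same words for both pairs, so it is the same change.

The expectation for compound 4 rests on compound 1 and compound 2, because a 1.5-fold higher number from compound 1 to compound 2 (0.19 log units; within the scatter) was within the scatter. Compound 4 is therefore expected to show a 1.5-fold higher number from compound 3 to compound 4 (0.16 log units; within the scatter). Compound 4 is estimated at 25000 nM, with a likely range from 12000 nM to 55000 nM.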

Compound 4, half-maximal inhibitory concentration: 27200 nM
Beside the measured number, compound 4's estimate is 1.1-fold (0.04 log units) below it; measured number inside the range.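

In this assay the swap of 3-nitrophenyl for 4-methylphenyl on a carbonyl carbon gave a 1.6-fold higher number from compound 3 to compound 4 (0.20 log units; within the scatter) on the core of compound 3, and it reads alike on the two cores: the same change on two cores in this assay, a 1.5-fold higher number (0.19 log units; within the scatter) from compound 1 to compound 2 and a 1.6-fold higher number (0.20 log units; within the scatter) from compound 3 to compound 4, 1.0-fold (0.02 log units) apart, within the scatter of two such steps. So, within this small set, the step on the core of compound 1 and the step on the core of compound 3 cannot be told apart, and the swap carried over without any sign that the core altered its outcome. Each step lies within the scatter, however, so the pairs do not show that the swap has any real effect on either core, and two pairs cannot show that it would read the same on a third core.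

What the compounds shown leave open is whether an aromatic ring bearing an amine or a carboxylic acid, or a longer alkyl chain, on that carbonyl carbon would give a step beyond the scatter. They also leave open whether any such step would then carry from one core to the other.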